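The source may hold more compounds than are shown below. What is called first, only, known or untested is meant among the compounds shown, and "the series" means these compounds.

Compound 1 `CCc1cccc(NS(=O)(=O)c2ccc(N3CCNC3=O)cc2)c1` is the reference point of this pair of notes. In a functional assay on HT-1080 cells (Homo sapiens) for antiproliferative activity, read by sulforhodamine B assay, with a stated time of 48 h (on this read-out higher numbers stand for weaker inhibition and lower numbers for stronger inhibition), compound 1 gives 200 nM, the highest of the two numbers recorded so far. For the measured compounds named here, compound 2 `O=C1NCCN1c1ccc(S(=O)(=O)Nc2cccc(Cl)c2)cc1` is its only measured neighbour; in this assay compound 2 gives 68 nM, and the single recorded step, a 2.9-fold lower number from compound 1 to compound 2 (0.47 log units; beyond the scatter), is a modest lowering that exceeds the usual scatter.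

Compound 3 `COc1cccc(NS(=O)(=O)c2ccc(N3CCNC3=O)cc2)c1` is the next unmeasured candidate. Relative to compound 1 it carries methoxy in place of ethyl on an aromatic carbon, so the 3-ethylphenyl of compound 1 becomes 3-methoxyphenyl. Going by the values given here, the only step that bears on this change is the one from compound 1 to compound 2, which alters the same aromatic carbon and moved the number by a 2.9-fold lower number from compound 1 to compound 2 (0.47 log units; beyond the scatter); no measured compound yet holds a methoxy here, so the direction of the new step is open. A small shift, within or just beyond the scatter, is the expectation for compound 3, with no firm basis for a larger move.

For compound 3 the estimated result in this assay is 150 nM, with a range of 50 nM to 450 nM, which would correspond to an expected step of a 1.3-fold lower number from compound 1 to compound 3 (0.12 log units; within the scatter).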

Compound 3, half-maximal inhibitory concentration: 200 nM
The estimate for compound 3 lay 1.3-fold (0.12 log units) below the measured number; the range from low to high includes it.
By their numbers in this assay, from the lowest: compound 2; then compounds 1 and 3 (each within the scatter of the next).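

In this assay, the change from ethyl to methoxy on this aromatic carbon gives no change at the digits printed from compound 1 to compound 3 (within the scatter). Exchanging a carbon for an oxygen in a group of the same heavy-atom count, and gaining a hydrogen-bond acceptor in the process, therefore does not separate the two compounds in this read-out. Chloro now stands apart from two different groups rather than from ethyl alone, with a 2.9-fold higher number from compound 2 to compound 3 (0.47 log units; beyond the scatter), and nothing at hand gives a reason for this difference or for the lack of one between ethyl and methoxy.

The three compounds leave open whether the lower number of compound 2 belongs to chloro alone or extends to other halogens such as fluoro or bromo, or to a group such as trifluoromethyl or nitrile. Also open, on these data alone, is how this position would respond to a larger departure from the groups seen so far, such as an amine, a carboxylic acid or a longer alkyl chain.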